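The compounds below may be only part of what the source reports. "The series", "measured", "known", "first", "only" and "open" are said of these compounds alone.

Measured compounds in a functional assay on THP-1 cells (Homo sapiens) for inhibition, read by ELISA, with stated times of 2 h and 48 h; a lower number here means a stronger inhibitor, a higher number a weaker inhibitor:

Compound 1, `CCOC1=C(/C(C)=N/OCC(=O)Nc2cccc(F)c2)N(C)S(=O)(=O)c2ccccc21`. In this assay compound 1 gives only a limit, > 20000 nM.
Compound 2, `CCOC1=C(/C(C)=N/OCC(=O)Nc2cccc(OC)c2)N(C)S(=O)(=O)c2ccccc21`. In this assay compound 2 gives only a limit, > 20000 nM.
Compound 3, `C/C(=N\OCC(=O)Nc1cccc(F)c1)C1=C(O)c2ccccc2S(=O)(=O)N1C`. In this assay compound 3 gives only a limit, > 20000 nM.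

Compound 3 therefore stands at the limit of this assay, as do the other two: the limit of > 20000 nM in this assay, at which 3 of the 3 values shown sit. No numbered value exists anywhere in the set against which to place it.

The unmeasured compound is compound 4, `C/C(=N\OCC(=O)Nc1ccc(C(F)(F)F)cc1)C1=C(O)c2ccccc2S(=O)(=O)N1C`. Its difference from compound 3 is 4-(trifluoromethyl)phenyl in place of 3-fluorophenyl on an amide-type nitrogen.

The two measured steps are a step that the two limits leave unreadable from compound 1 to compound 2 and a step that the two limits leave unreadable from compound 1 to compound 3. Neither bears directly on the exchange at the amide-type nitrogen made in compound 4, and neither is readable in size, since both ends sit at the limit. Among the measured compounds shown here, there is thus no measured step from which a direction or size can be taken; the only guide is that every compound of the shared core so far has failed to show measurable inhibition in this assay.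

The expectation for compound 4 is therefore that it, too, will most likely be reported only as a limit, and the expected step that the limit leaves unreadable from compound 3 to compound 4 is none beyond the scatter. Compound 4 is estimated at 30000 nM, with a range from 8000 nM to 120000 nM.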

Compound 4, half-maximal inhibitory concentration: > 20000 nM
Compound 4: no number, only a limit; the forecaster's own chance of this, stated with the estimate: 85%; the middle value is on the limit's open side.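

Compound 3 and compound 4 both stand only as limits, so no step can be read between them: the limit of > 20000 nM in this assay, at which 4 of the 4 values shown sit.

The compounds shown leave open whether any compound on the shared core reaches a numbered half-maximal inhibitory concentration in this assay, and so whether the group on the amide-type nitrogen changes inhibition at all.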